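The source may report more compounds than this note shows. Statements on the series, on what has been measured and on what is new or still open speak of the compounds shown alone.

In this assay a functional assay on NCI-H460 cells (Homo sapiens) for antiproliferative activity, with a stated time of 72 h (on this read-out lower numbers stand for stronger inhibition and higher numbers for weaker inhibition), compound 2 `C=CC[C@H]1C[C@]2([C@@H](C)Cc3ccc(OC)c(NC(C)=O)c3)OCOC2=CC1=O` gives 310 nM, the higher of the two numbers recorded so far in the series, though its nearest neighbour sits within the scatter. Compound 1 `C=CC[C@H]1C[C@]2([C@@H](C)Cc3ccc(OC)c(OC)c3)OCOC2=CC1=O` gives 260 nM in this assay. Among the measured compounds shown here, the one single-point step recorded in the set is a 1.2-fold higher number from compound 1 to compound 2 (0.08 log units; within the scatter), arising from acetamido in place of methoxy on an aromatic carbon. Compound 3 `C=CC[C@H]1C[C@]2([C@@H](C)Cc3ccc(OC)c(Cl)c3)OCOC2=CC1=O` has not been measured in this assay; it differs from compound 2 by chloro in place of acetamido on an aromatic carbon. That one recorded step bears on the change, since it exchanges a group at the same aromatic carbon and produced no movement beyond the scatter. On that basis the step is expected to be small: a 1.1-fold lower number from compound 2 to compound 3 (0.04 log units; within the scatter), with no direction asserted beyond the scatter. The estimate for compound 3 in this assay is therefore 280 nM, with a range from 120 nM to 650 nM.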

Compound 3, half-maximal inhibitory concentration: 640 nM
Estimate against measurement, compound 3: 2.3-fold (0.36 log units) below; the range from low to high includes it.
By their numbers in this assay, from the lowest: compounds 1 and 2 (each within the scatter of the next); then compound 3.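

At this position, the aromatic carbon ortho to a methoxy group, the choice of group does register in this assay: chloro in place of acetamido gives a 2.1-fold higher number from compound 2 to compound 3 (0.31 log units; beyond the scatter), and chloro in place of methoxy gives a 2.5-fold higher number from compound 1 to compound 3 (0.39 log units; beyond the scatter). Among the compounds shown here, the earlier pair showed only a swap within the scatter, so this is the first sign that the position is not indifferent to what it carries, with chloro standing apart from the two groups that cannot be separated from each other. Nothing available accounts for the modest shift with chloro.

From the compounds shown here alone, whether the shift belongs to chloro alone or extends to fluoro or bromo remains open. Also open, going by these compounds, is whether an amine or a hydroxyl here would stay with compound 1 and compound 2 or move with compound 3.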